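A few compounds are considered here, and "the series" means these few. Any claim that something is new, unique, unknown or untested is made for them only; others in the source may bear on it.

In an in vitro ADME assay on microsomes from liver (Homo sapiens) for metabolic stability (a higher number here means faster removal of the compound, a lower number slower removal), compound 3 (`CC(C)Nc1nccc(-c2c[nH]nc2C2CCOCC2)n1`) gives 0.018 mL/min/kg, the lower of the two numeric values in the series, and the gap to compound 1 lies beyond the scatter. Compound 1 (`Clc1ccc(-c2n[nH]cc2-c2ccnc(NC3CC3)n2)cc1`) gives 0.096 mL/min/kg. Compound 2 (`C[C@H](CC(=O)O)Nc1nccc(-c2c[nH]nc2-c2ccc(Cl)cc2)n1`) returns only a limit of the assay, < 0.006 mL/min/kg. Compound 4 (`CC(C)Nc1nccc(-c2c[nH]nc2-c2ccc(Cl)cc2)n1`) has 4-chlorophenyl in place of oxan-4-yl on an aromatic carbon. For the measured compounds named here, the one measured step, an at least 16-fold lower number from compound 1 to compound 2 (1.20 log units; beyond the scatter), changes a group on a nitrogen, keeps 4-chlorophenyl and so gives no direct reading of this swap. The nearest guide, which shares 4-chlorophenyl with compound 4, is compound 1 at 0.096 mL/min/kg. An increase beyond the scatter is therefore expected in this assay, an estimated 4.4-fold higher number from compound 3 to compound 4 (0.65 log units; beyond the scatter). For compound 4 the estimated clearance is 0.08 mL/min/kg, with an expected range of 0.03 mL/min/kg to 0.2 mL/min/kg.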

Compound 4, clearance: 0.106 mL/min/kg
Compound 4: middle estimate off by 1.3-fold (0.12 log units), on the low side, within the range that was stated.
By their numbers in this assay, from the lowest: compound 3; then compounds 1 and 4 (each within the scatter of the next). At a limit, below all of these: compound 2.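

For this assay, the swap at this position now has a direct reading: 4-chlorophenyl in place of oxan-4-yl (a 5.9-fold higher number from compound 3 to compound 4 (0.77 log units; beyond the scatter)). With 4-chlorophenyl kept, isopropyl and cyclopropyl on the nitrogen do not separate (a 1.1-fold higher number from compound 1 to compound 4 (0.04 log units; within the scatter)). Removing the carboxy from the chain gives a clean single change (an at least 17-fold higher number from compound 2 to compound 4 (1.24 log units; beyond the scatter)), but that step starts from a limit of the assay, not a number: the limit of < 0.006 mL/min/kg in this assay, at which 1 of the 4 values shown sits.

Open, from the compounds shown here alone, is how phenyl without the chlorine, or piperidin-4-yl, would read at this position. Also open, going by these compounds, is how an amide in place of the carboxy would read on the chain.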